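Difluorophenyl analogue of compound 1: expected whole-animal dose

The source may report more compounds than this note shows. Statements on the series, on what has been measured and on what is new or still open speak of the compounds shown alone.

Compound 1 `Cn1nc(-c2ccccc2F)n(C)c1=S` is the lower of the two numbers measured in a functional assay on the whole organism with Mus musculus as the target; a higher number here means that more compound is needed for the effect, a lower number that less compound is needed; in this assay compound 1 gives 0.23 mg/kg. For the measured compounds named here, the only other measured compound, compound 2 `Cn1nc(-c2ccccc2Cl)n(C)c1=S`, gives 0.58 mg/kg, and the step of a 2.5-fold higher number from compound 1 to compound 2 (0.40 log units; beyond the scatter) is chloro in place of fluoro on an aromatic carbon. Compound 3 `Cn1nc(-c2ccc(F)cc2F)n(C)c1=S` is not yet measured.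

Compound 3 differs from compound 1 in this way: fluoro in place of hydrogen on an aromatic carbon. Going by the values given here, no measured step of this kind, a fluoro entering for hydrogen, exists; the one measured step concerns an exchange of halogens on the same ring and was modest. What it shows is that a single-atom change on that ring can move the dose by a modest amount, and nothing points to a large change. The expectation for compound 3 is therefore a step of about a 1.3-fold higher number from compound 1 to compound 3 (0.12 log units; within the scatter), which may well fall within the scatter. The estimated dose of compound 3 in this assay is 0.3 mg/kg, with a range from 0.12 mg/kg to 0.75 mg/kg.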

Compound 3, dose for half-maximal effect: 2.37 mg/kg
For compound 3 the middle estimate is 7.9-fold (0.90 log units) below the measured one; measured number outside the range, above it.
By their numbers in this assay, from the lowest: compound 1; then compound 2; then compound 3.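

In this assay, fluoro in place of hydrogen gives a 10-fold higher number from compound 1 to compound 3 (1.01 log units; beyond the scatter), a large step, whereas the halogen exchange giving a 2.5-fold higher number from compound 1 to compound 2 (0.40 log units; beyond the scatter) was modest. This place on the ring, meta to a fluoro group and para to a group of 8 heavy atoms, is therefore not indifferent to substitution: the entry of a single heavy atom here is enough to raise the dose needed for the effect substantially, which the halogen exchange alone did not reveal. Nothing available bears on what lies behind this step, and the result stands as an observation on the whole animal only.

The compounds shown leave open whether the step is peculiar to fluoro or would also follow from a chloro, a methoxy group or an amine at this place on the ring. Also open, as far as these compounds go, is whether the step depends on the fluoro group already on the ring, a question that the same entry on a ring bearing chloro or no halogen at all would address.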